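Chain extension on a shared triazine-free core? No — a shared core

This account rests on a few compounds, and the source may have more. Where it says the series, first, only, none or still open, it means among the compounds named here.

compound 1, `Nc1nc(NCc2ccc(Cl)cc2)nc(-c2ccccc2CO)n1`: 5.22
compound 2, `Nc1nc(NCc2ccc(C(F)(F)F)cc2)nc(-c2ccccc2CO)n1`: 5.03
compound 3, `CCOc1ccc(CNc2nc(N)nc(-c3ccccc3CO)n2)cc1`: 4.77

All three compounds were tested in a functional assay on cells for positive allosteric modulation of G-protein coupled receptor 68 (Homo sapiens), read by a luciferase reporter and cAMP accumulation, with a stated time of 30 min, at pH 6.8 and pH 8.3, in the presence of a further agent that is not named here (on this read-out lower numbers stand for lower potency and higher numbers for higher potency (the scale is a negative logarithm)), and share one core, differing only in the group on the aromatic ring of the benzylic substituent. Compound 1 carries the highest of the three numbers. Compound 2 is nearest, with a number 0.19 log units lower from compound 1 to compound 2 (within the scatter), which is within the scatter, so no order between these two can be claimed. Compound 3 is furthest, with a number 0.45 log units lower from compound 1 to compound 3 (beyond the scatter), beyond the scatter though modest. Between the other two, a number 0.26 log units lower from compound 2 to compound 3 (within the scatter) is within the scatter.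

Compound 4, `Nc1nc(NCCCc2ccccc2)nc(-c2ccccc2CO)n1`, has not been measured. It differs from compound 1 by phenethyl in place of 4-chlorophenyl on a saturated chain carbon bound to a nitrogen on an aromatic ring. For the measured compounds named here, none of the measured steps makes a change of this kind: each exchanges one group on the aromatic ring for another, whereas here the whole ring-bearing group is replaced. The measured steps all run downward from compound 1 and stay small, so a small downward step is expected here too, with wide uncertainty: the expected step is a number 0.32 log units lower from compound 1 to compound 4 (beyond the scatter). Compound 4 is expected to give 4.9 in this assay, with a range from 4.4 to 5.4.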

Compound 4, negative logarithm of the antagonist equilibrium constant: 5.22
Estimate against measurement, compound 4: 0.32 log units below, within the range that was stated.
By their numbers in this assay, from the lowest: compounds 3, 2, 1 and 4 (each within the scatter of the next, the first and the last beyond it).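

Putting phenethyl in place of 4-chlorophenyl, on a saturated chain carbon bound to a nitrogen on an aromatic ring, gives no change at the digits printed from compound 1 to compound 4 (within the scatter) in this assay. The earlier compounds shown here exchanged only a group on the aromatic ring, whereas this step replaces the whole ring-bearing group, and compound 4, which carries no chlorine, still reads level with compound 1, so at this place neither the chlorine nor the exact 4-chlorophenyl group is needed to keep that number. Nothing measured here explains why the two groups read alike.

On these data alone, whether a longer chain than phenethyl would hold the number is still open. So is what would happen with an amine or a carboxylic acid on the aromatic ring of phenethyl.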